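Benzyl for methyl on the amine across two cores

The compounds below may be only part of what the source reports. "The series", "measured", "known", "first", "only" and "open" are said of these compounds alone.

Measured compounds:
- Compound 1 `CC[C@@]1(c2ccccc2)OCC[C@@H](CCNC)O1`: in an assay for displacement of a labelled ligand from Sigma non-opioid intracellular receptor 1 (Cavia porcellus), read by scintillation counting (on this read-out lower numbers stand for stronger inhibition and higher numbers for weaker inhibition), compound 1 gives 856 nM.
- Compound 2 `CC[C@@]1(c2ccccc2)OCC[C@@H](CCNCc2ccccc2)O1`: in this assay compound 2 gives 27 nM.
- Compound 3 `CNCCC[C@@H]1CCO[C@H](c2ccccc2)O1`: in this assay compound 3 gives 327 nM.

Compound 1 and compound 2 share one core and differ only at the amine. The change between them is phenyl in place of hydrogen on a saturated chain carbon bound to an amine nitrogen. Its effect is a 32-fold lower number from compound 1 to compound 2 (1.50 log units; beyond the scatter), a large step and well beyond the scatter of the measurement.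

Compound 3 carries a different core. The difference between the core of compound 3 and the core of compound 1 is not broken down here. Of the three measured numbers, compound 3 stands second highest: beyond the scatter higher than compound 1 when the two values are set side by side, and far above compound 2.

Compound 4 `c1ccc(CNCCC[C@@H]2CCO[C@H](c3ccccc3)O2)cc1` is not yet measured. It differs from compound 3 by phenyl in place of hydrogen on a saturated chain carbon bound to an amine nitrogen. The place line reads the same as for the change from compound 1 to compound 2, so this is the same change, made once before among the compounds shown. For the measured compounds named here, only that single earlier instance is available as a guide, on a different core.

For compound 4 the expectation in this assay is a step of about a 22-fold lower number from compound 3 to compound 4 (1.34 log units; beyond the scatter), resting on the step seen in a 32-fold lower number from compound 1 to compound 2 (1.50 log units; beyond the scatter) and on the starting value of compound 3, 327 nM. Going by the values given here, with only one precedent, some shrinkage of the step is assumed. Compound 4 is thus estimated at 15 nM, with a plausible range from 4 nM to 55 nM.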

Compound 4, inhibition constant: 164 nM
The estimate for compound 4 lay 11-fold (1.04 log units) below the measured number, outside the stated range (above it).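

In this assay, the change from methyl to benzyl on the amine does not carry over from one core to the other at the same size: the same change on two cores in this assay, a 32-fold lower number (1.50 log units; beyond the scatter) from compound 1 to compound 2 and a 2.0-fold lower number (0.30 log units; within the scatter) from compound 3 to compound 4, 16-fold (1.20 log units) apart, beyond the scatter of two such steps

On the core of the second pair the change gives a 2.0-fold lower number from compound 3 to compound 4 (0.30 log units; within the scatter), so there the two amines cannot be told apart on this read-out, while on the core of the first pair the same change gives a 32-fold lower number from compound 1 to compound 2 (1.50 log units; beyond the scatter). For the compounds shown here, this shows that the large step is not a fixed increment of the benzyl group, and that an amine change read on one core is a poor guide to the other; it does not show which part of the core sets the size of the step, since the two cores are not broken down into single changes, and each core offers only one pair.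

Which part of the core accounts for the gap stays open, as it would take pairs that change one core feature at a time with the amine held fixed. Also open, from the compounds shown here alone, is whether a phenethyl group, or a tertiary amine carrying both methyl and benzyl, would follow compound 2 or compound 4 on each core.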